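Thiazolyl thioether swap on an inactive pair

The source may hold more compounds than are shown below. What is called first, only, known or untested is meant among the compounds shown, and "the series" means these compounds.

compound 1 `C#CCSc1nc(Sc2nc3ccccc3s2)c(C#N)c(-c2cc(OC)c(OC)c(OC)c2)n1` — > 20000 nM
compound 2 `C#CCSc1nc(Sc2nccs2)c(C#N)c(-c2ccc[nH]2)n1` — > 20000 nM

In a functional assay on PC-9 cells (Homo sapiens) for antiproliferative activity, read by MTT assay (a lower number here means a stronger inhibitor, a higher number a weaker inhibitor), compound 1 gives > 20000 nM, which is a limit of the assay and not a number. Compound 2 gives > 20000 nM in this assay, likewise a limit. Both values sit at the limit of > 20000 nM in this assay, at which 2 of the 2 values shown sit, so on the numbers shown compound 1 is not distinguishable from compound 2. Compound 3 `C#CCSc1nc(Sc2nc(C)cs2)c(C#N)c(-c2cc(OC)c(OC)c(OC)c2)n1` is not yet measured. The change is 4-methyl-1,3-thiazol-2-yl in place of 1,3-benzothiazol-2-yl on a sulfur. Going by the values given here, no step between measured compounds is known; the step that the limit leaves unreadable from compound 1 to compound 3 is expected to stay within the scatter, with compound 3 most likely again at the limit. Compound 3 is estimated at 25000 nM, between 8000 nM and 80000 nM.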

Compound 3, half-maximal inhibitory concentration: > 20000 nM
Compound 3 was reported as a limit; the forecaster's own chance of this, stated with the estimate: 75%; the middle value lies beyond the limit too.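

Compound 1 and compound 3 are both limits and not numbers, so no step can be read between them: the limit of > 20000 nM in this assay, at which 3 of the 3 values shown sit.

The compounds shown leave open whether any analogue of the shared core gives a measurable value in this assay.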